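A Methoxy Group Replacing Hydrogen on an Inactive Core

The source may hold more compounds than are shown below. What is called first, only, known or untested is meant among the compounds shown, and "the series" means these compounds.

Compound 1 `O=c1[nH]nc2n(c1=O)CCN2c1ccccc1` was tested in a functional assay on A549 cells (Homo sapiens) for antiproliferative activity, with a stated time of 72 h, tested at 10 ug/mL (a higher number here means a stronger effect of the compound at the concentration tested, a lower number a weaker effect), where compound 1 gives 0%. Compound 2 `O=c1[nH]nc2n(c1=O)CCN2c1cccc(Cl)c1` carries chloro in place of hydrogen on an aromatic carbon, and in this assay compound 2 gives 0%. The step from compound 1 to compound 2 was no change at the digits printed from compound 1 to compound 2 (within the scatter). Compound 1 thus stands level with compound 2 at the digits shown, and neither compound shows any effect at the concentration tested.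

Compound 3 `COc1ccc(N2CCn3c2n[nH]c(=O)c3=O)cc1` differs from compound 1 in one place: methoxy in place of hydrogen on an aromatic carbon. Among the compounds with values here, the one measured step that bears on this change, a substituent entering on an aromatic carbon, gave no change at the digits printed from compound 1 to compound 2 (within the scatter). Since nothing in the measured pair moved the read-out, the expected step of no change at the digits printed from compound 1 to compound 3 (within the scatter) is none beyond the scatter. Compound 3 is accordingly estimated at 0%, with a range from 0% to 12%.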

Compound 3, a percentage reported as inhibition, at one concentration (the size of the read-out at that concentration, not a potency): 0%
Compound 3: the middle estimate sits on the measured number at the digits printed; the range from low to high includes it.
By their numbers in this assay, from the lowest: compounds 1, 2 and 3 (each within the scatter of the next).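

Methoxy, entering on an aromatic carbon para to a large group, gave no change at the digits printed from compound 1 to compound 3 (within the scatter) in this assay. This adds a group with an oxygen and a hydrogen-bond acceptor to the changes on the aromatic ring of compound 1 that leave the read-out unmoved, and this position para to a large group now has a measured result of its own. No supporting measurement bears on why the read-out stays the same.

On these data alone, whether an amine or a carboxylic acid at this position, or a longer chain in place of methoxy, would give compound 1's scaffold a read-out beyond the scatter remains open. Also open, as far as these compounds go, is whether the shared core shows any effect at a concentration higher than the one tested.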